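Isobutyl in place of ethyl on the shared core

The source may report more compounds than this note shows. Statements on the series, on what has been measured and on what is new or still open speak of the compounds shown alone.

Compound 1 `CCc1ccc(NS(=O)(=O)c2ccc(N3CCNC3=O)cc2)cc1` stands as the weakest of the three measured compounds in a functional assay on HT-29 cells (Homo sapiens) for antiproliferative activity, read by sulforhodamine B assay, with a stated time of 48 h; a lower number here means a stronger inhibitor, a higher number a weaker inhibitor: compound 1 gives 660 nM. Both of its measured neighbours lie beyond the scatter from it. Compound 2 `Cc1ccc(C)c(NS(=O)(=O)c2ccc(N3CCNC3=O)cc2)c1` gives 46 nM, a change of a 14-fold lower number from compound 1 to compound 2 (1.16 log units; beyond the scatter), and compound 3 `O=C1NCCN1c1ccc(S(=O)(=O)Nc2cccc(Cl)c2)cc1` gives 55 nM, a change of a 12-fold lower number from compound 1 to compound 3 (1.08 log units; beyond the scatter). Between compound 2 and compound 3 the gap is a 1.2-fold higher number from compound 2 to compound 3 (0.08 log units; within the scatter), within the scatter.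

Compound 4 `CC(C)Cc1ccc(NS(=O)(=O)c2ccc(N3CCNC3=O)cc2)cc1` differs from compound 1 by isopropyl in place of methyl on a saturated chain carbon bound to an aromatic carbon. Among the compounds with values here, none of the measured steps bears on this change. The step to compound 2 and the step to compound 3 each exchange the whole aryl group on the sulfonamide nitrogen for a differently substituted one, whereas compound 4 keeps the aryl group of compound 1 and only extends the alkyl chain on it. Within the data shown here, with no measured step of that kind, a change beyond the scatter is not expected in either direction in this assay. Compound 4 is therefore estimated at 660 nM, with a range from 250 nM to 1800 nM. The step this expectation means is no change at the digits printed from compound 1 to compound 4 (within the scatter).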

Compound 4, half-maximal inhibitory concentration: > 1000 nM
Compound 4: no number, only a limit; the forecaster's own chance of this, stated with the estimate: 5%; at least 1.5-fold (0.18 log units) between middle value and limit.
By their numbers in this assay, from the lowest: compounds 2 and 3 (each within the scatter of the next); then compound 1. At a limit, above all of these: compound 4.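

In this assay compound 4 gives > 1000 nM, which is a limit of the assay and not a number. Within the data shown here, this is the first measured change that keeps the aryl group of compound 1 and alters only its alkyl chain, ethyl to isobutyl, and the step reads an at least 1.5-fold higher number from compound 1 to compound 4 (0.18 log units; that floor lies within the scatter), so the larger chain brings no gain in this assay, while the floor of that step does not by itself separate compound 4 from compound 1 and the full size of the change stays unknown. Only this one compound of those shown sits at such a limit, so the step gives a direction at most and no measured distance: the limit of > 1000 nM in this assay, at which 1 of the 4 values shown sits.

What the compounds shown leave open is how the number moves with a propyl group or a longer straight chain in place of ethyl, and whether an amine or a carboxylic acid carried on that chain would read as isobutyl does. They also leave open whether an isobutyl group would have any such effect on the differently substituted aryl groups of compound 2 and compound 3.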